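Amide variation on the shared core

A few compounds are considered here, and "the series" means these few. Any claim that something is new, unique, unknown or untested is made for them only; others in the source may bear on it.

compound 1 `Cn1cc(-c2cnc3ccc(N)nc3c2)cn1` — > 50000 nM (a limit)
compound 2 `Cn1cc(-c2cnc3ccc(NC(=O)c4ccc(F)cc4)nc3c2)cn1` — > 50000 nM (a limit)

In a functional assay on HeLa cells (Homo sapiens) for antiproliferative activity, read by MTT assay, with a stated time of 48 h (on this read-out lower numbers stand for stronger inhibition and higher numbers for weaker inhibition), compound 1 gives only a limit, > 50000 nM. Compound 2 likewise gives only a limit, > 50000 nM. Compound 2 thus stands at the limit of > 50000 nM in this assay, at which 2 of the 2 values shown sit, with no number to compare against.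

Compound 3 `Cn1cc(-c2cnc3ccc(NC(=O)c4cccnc4)nc3c2)cn1` differs from compound 2 by pyridin-3-yl in place of 4-fluorophenyl on a carbonyl carbon. Going by the values given here, no measured step covers this change, and both reference points are limits; the expected step in this assay is none beyond the scatter, most likely another limit. Compound 3 is estimated at 50000 nM, between 20000 nM and 120000 nM, an expected change of a number no higher from compound 2 to compound 3 (the limit leaves the size open).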

Compound 3, half-maximal inhibitory concentration: > 50000 nM
Compound 3: only a limit was reported (the forecaster's own chance of this, stated with the estimate: 80%); the middle value sits exactly at the limit.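

In this assay compound 3 gives only a limit, > 50000 nM, so no step from compound 1 or compound 2 to compound 3 can be read: the limit of > 50000 nM in this assay, at which 3 of the 3 values shown sit.

The compounds shown leave open whether any amide on the shared core gives a measurable number in this assay at all.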